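Chloro for methyl on the pendant phenyl of compound 3

A few compounds are considered here, and "the series" means these few. Any claim that something is new, unique, unknown or untested is made for them only; others in the source may bear on it.

Working notes on the series. Compound 3 `Cc1ccc(-c2nn(-c3cccc(Cl)c3)c(N)c2C=O)cc1` gives 86300 nM in a functional assay on Jurkat cells (Homo sapiens) for inhibition, read by MTT assay, with a stated time of 72 h (on this read-out lower numbers stand for stronger inhibition of growth and higher numbers for weaker inhibition of growth), the higher of the two numbers reported. Compound 2 `CN(C)/C=N/c1c(C=O)c(-c2ccc(Cl)cc2)nn1-c1cccc(Cl)c1` gives 7700 nM in this assay, and the two values lie beyond the scatter of each other. Compound 1 `Nc1cc(-c2ccc(Cl)cc2)nn1-c1cccc(Cl)c1` gives only a limit, > 100000 nM, in this assay. Compound 4 `Nc1c(C=O)c(-c2ccc(Cl)cc2)nn1-c1cccc(Cl)c1` is not yet measured; it differs from compound 3 by chloro in place of methyl on an aromatic carbon, read one bond further out as 4-methylphenyl to 4-chlorophenyl. Going by the values given here, no step between measured compounds covers this change. A modest step toward a lower number is expected, a 2.2-fold lower number from compound 3 to compound 4 (0.33 log units; beyond the scatter), possibly within the scatter. Compound 4 is expected to give about 40000 nM in this assay, between 10000 nM and 100000 nM.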

Compound 4, concentration for 50% growth inhibition: 78900 nM
Compound 4: the middle estimate sits 2.0-fold (0.30 log units) below what was measured; measured number inside the range.
By their numbers in this assay, from the lowest: compound 2; then compounds 4 and 3 (each within the scatter of the next). At a limit, above all of these: compound 1.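

In this assay, chloro in place of methyl on an aromatic carbon stays within the scatter: a 1.1-fold lower number from compound 3 to compound 4 (0.04 log units; within the scatter). The large change lies elsewhere, with one nitrogen atom in place of a group of 5 heavy atoms: a 10-fold higher number from compound 2 to compound 4 (1.01 log units; beyond the scatter). Formyl in place of hydrogen on an aromatic carbon can be given only as a floor: an at least 1.2-fold lower number from compound 1 to compound 4 (0.10 log units; that floor lies within the scatter). Compound 1 gives only a limit: the limit of > 100000 nM in this assay, at which 1 of the 4 values shown sits.

As far as these compounds go, whether a methoxy or a trifluoromethyl group at this place would also leave the number unchanged stays open. So does whether an acetamide in place of the amine would retain the lower number of compound 2.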